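Fluorophenyl positional swap on the shared core

The source may hold more compounds than are shown below. What is called first, only, known or untested is meant among the compounds shown, and "the series" means these compounds.

Measured so far:
compound 1 `COc1cc(C2=NN(C(C)=O)C(c3cccc(F)c3)O2)cc(OC)c1OC`: 16.5%
compound 2 `COc1ccc(OC)c(/C=N/NC(=O)c2cc(OC)c(OC)c(OC)c2)c1`: 30.9%
compound 3 `COc1cc(C(=O)N/N=C/c2ccccc2F)cc(OC)c1OC`: 70.6%

In a functional assay on PC-3 cells (Homo sapiens) for antiproliferative activity, read by MTT assay, tested at 1 uM (a lower number here means a weaker effect, a higher number a stronger effect of the compound at the concentration tested), compound 1 gives the lowest of the three numbers. Compound 2 sits closest, higher by a margin beyond the scatter, and compound 3 stands furthest, well beyond the scatter. For the measured compounds named here, no step between two measured compounds differing in a single place is available, so the series offers no direct calibration for the change at hand.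

Compound 4 `COc1cc(C2=NN(C(C)=O)C(c3ccc(F)cc3)O2)cc(OC)c1OC` keeps the core of compound 1 and differs only as follows: 4-fluorophenyl in place of 3-fluorophenyl on a saturated ring carbon.

With nothing in the measured set to calibrate this swap, the expected step is one that stays within the scatter, with no direction favoured. Compound 4 is expected to give 20% in this assay, between 6% and 40%. That estimate means a step of a number 3.5 percentage points higher from compound 1 to compound 4 (within the scatter).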

Compound 4, a percentage reported as inhibition, at one concentration (the size of the read-out at that concentration, not a potency): 0%
Compound 4: the middle estimate sits 20 percentage points above what was measured; the measured number lies below the stated range.
By their numbers in this assay, from the lowest: compound 4; then compound 1; then compound 2; then compound 3.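

In this assay, 4-fluorophenyl in place of 3-fluorophenyl on the saturated ring carbon gives a step of a number 16.5 percentage points lower from compound 1 to compound 4 (beyond the scatter). This is the series' first single-place calibration: the atoms stay the same, and the fluorine's place on the phenyl ring alone separates the pair beyond the scatter. Nothing available bears on the reason for this step. Still open, as far as these compounds go, is how a plain phenyl or a 4-aminophenyl would read on this ring carbon. Also open, from the compounds shown here alone, is whether a propionyl group in place of the acetyl group would preserve the step.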